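Dropping the Methyl from Compound 3

This account rests on a few compounds, and the source may have more. Where it says the series, first, only, none or still open, it means among the compounds named here.

Compound 3 `CN(c1ccc(Oc2ncnc3sccc23)cc1)c1nccc(N2CCCC2)n1` stands lowest of the three compounds measured in a functional assay on HCT-116 cells (Homo sapiens) for inhibition, read by MTT assay, with a stated time of 72 h, tested at 20 uM (a lower number here means less inhibition, a higher number more inhibition at the concentration tested (going by the name of the read-out)), where compound 3 gives 42.2%. Compound 2 `CN(c1ccc(Oc2ncnc3ccsc23)cc1)c1nccc(N2CCCC2)n1` gives 63.6%, and compound 1 `c1cc(N2CCCCC2)nc(Nc2ccc(Oc3ncnc4sccc34)cc2)n1` gives 66.3%. Among the measured compounds shown here, the only single-change step known, a number 21.4 percentage points lower from compound 2 to compound 3 (beyond the scatter), concerns the swap of aromatic groups on the ether oxygen and does not bear on the change to compound 4 `c1cc(N2CCCC2)nc(Nc2ccc(Oc3ncnc4sccc34)cc2)n1`, which is hydrogen in place of methyl on a nitrogen on an aromatic ring. For the measured compounds named here, no measured step isolates this change; compound 1, which carries the same hydrogen on its aromatic nitrogen, differs from compound 4 in its ring and so only hints that a higher value is plausible. The expected step is a number 13.8 percentage points higher from compound 3 to compound 4 (beyond the scatter), with compound 4 estimated at 56% within 36% to 76%.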

Compound 4, a percentage reported as inhibition, at one concentration (the size of the read-out at that concentration, not a potency): 54.4%
For compound 4 the middle estimate is 1.6 percentage points above the measured one; the measured number falls inside the stated range.
By their numbers in this assay, from the lowest: compound 3; then compounds 4, 2 and 1 (each within the scatter of the next, the first and the last beyond it).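

In this assay, among the compounds shown here, hydrogen in place of methyl on the nitrogen gives the first direct reading of this change, a number 12.2 percentage points higher from compound 3 to compound 4 (beyond the scatter). The same result also isolates the ring on the aromatic carbon: pyrrolidin-1-yl in place of piperidin-1-yl gives a number 11.9 percentage points lower from compound 1 to compound 4 (beyond the scatter). Nothing at hand explains either step. The compounds shown leave open how an ethyl or an acetyl on that nitrogen would read, and whether the methyl-to-hydrogen step would hold with the aromatic group that compound 2 carries on its ether oxygen.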